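Trifluoromethoxy in place of fluoro on the aromatic ring

A few compounds are considered here, and "the series" means these few. Any claim that something is new, unique, unknown or untested is made for them only; others in the source may bear on it.

In an ADME assay on microsomes from liver (Rattus norvegicus) for metabolic stability, read by LC-MS, using NADPH, with a stated time of 10 min, tested at 0.5 uM (on this read-out lower numbers stand for a less stable compound and higher numbers for a more stable compound), compound 1 (`CC(=O)Nc1cc(-c2ccc(OC[C@@](C)(N)CC(C)C)c(F)c2)ccn1`) gives 92%, compound 2 (`CC(=O)Nc1cc(-c2ccc(OC[C@@H](N)CC(C)C)c(F)c2)ccn1`) gives 80% and compound 3 (`CC(=O)Nc1cc(-c2cc(F)c(OC[C@@H](N)CC(C)C)cc2F)ccn1`) gives 90%. Compound 2 thus has the smaller number against compound 1, and it is level within the scatter with compound 3.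

Compound 4 (`CC(=O)Nc1cc(-c2ccc(OC[C@@H](N)CC(C)C)c(OC(F)(F)F)c2)ccn1`) is compound 2 with trifluoromethoxy in place of fluoro on an aromatic carbon, ortho to a (2-amino-4-methylpentyl)oxy group: trifluoromethoxy in place of fluoro on an aromatic carbon.

The change on the saturated chain, a number 12 percentage points lower from compound 1 to compound 2 (beyond the scatter), lies away from this aromatic carbon and bears on the new change only loosely. Among the compounds with values here, the change on an aromatic carbon, a number 10 percentage points higher from compound 2 to compound 3 (within the scatter), is closer in kind, but it adds fluoro in place of hydrogen, and no measured compound carries trifluoromethoxy. On these data alone, no step beyond the scatter is therefore expected in this assay, and the direction stays open. The expected step is a number 2 percentage points lower from compound 2 to compound 4 (within the scatter). For compound 4 the estimate is 78%, with an expected range of 62% to 90%.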

Compound 4, percent of the compound remaining: 80%
The estimate for compound 4 lay 2 percentage points below the measured number; the measured number falls inside the stated range.
By their numbers in this assay, from the lowest: compounds 2, 4, 3 and 1 (each within the scatter of the next, the first and the last beyond it).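

Trifluoromethoxy in place of fluoro on the aromatic carbon ortho to a (2-amino-4-methylpentyl)oxy group gives no change at the digits printed from compound 2 to compound 4 (within the scatter) in this assay. Within the data shown here, in compounds 1, 2 and 3 this carbon carries only fluoro, so compound 4 is the first sign that five heavy atoms, one of them a hydrogen-bond acceptor, can stand here in place of one without a step beyond the scatter in this read-out. No measured property is at hand to account for this result.

On these data alone, whether a methoxy group, a chlorine or a nitrile at this carbon would stay level with fluoro remains open. Also open, as far as these compounds go, is whether trifluoromethoxy would hold its number alongside the 1-amino-1,3-dimethylbutyl chain of compound 1 or the second fluoro of compound 3.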